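The source may report more compounds than this note shows. Statements on the series, on what has been measured and on what is new or still open speak of the compounds shown alone.

Working notes on the series built around the shared core of compound 1 `CS(=O)(=O)Nc1ccc2c(c1)S(=O)(=O)N=C(C1=C(O)C3CCCC3N(Cc3ccc(F)cn3)C1=O)N2`. In an ADME assay on Huh-7 cells (Homo sapiens) for cytotoxicity, with a stated time of 72 h (on this read-out lower numbers stand for higher toxicity in this test and higher numbers for lower toxicity in this test), compound 1 reports only a limit, > 33000 nM. Compound 2 `CS(=O)(=O)Nc1ccc2c(c1)S(=O)(=O)N=C(C1=C(O)[C@H]3CCC[C@H]3N(Cc3ccc(F)c(F)c3)C1=O)N2` likewise gives a limit in this assay, > 1000 nM. Compound 3 `CS(=O)(=O)Nc1ccc2c(c1)S(=O)(=O)N=C(C1=C(O)C3CCCCC3N(C3CCCCC3)C1=O)N2` also stops at a limit, > 33000 nM. Compound 1 therefore sits at the limit of > 33000 nM in this assay, at which 2 of the 3 values shown sit, while the limit of > 1000 nM in this assay, at which 1 of the 3 values shown sits, is a different threshold, so no order among the three can be drawn. Compound 4 `CCN1C(=O)C(C2=NS(=O)(=O)c3cc(NS(C)(=O)=O)ccc3N2)=C(O)C2CCCC21` carries methyl in place of 5-fluoropyridin-2-yl on a saturated chain carbon bound to an amide-type nitrogen in a ring, methyl in place of 5-fluoropyridin-2-yl on a saturated chain carbon bound to an amide-type nitrogen in a ring, read one bond further out as (5-fluoropyridin-2-yl)methyl to ethyl. Among the compounds with values here, no measured step covers this change; the expectation is no shift beyond the usual scatter. Compound 4 is estimated at 40000 nM, within 20000 nM to 100000 nM. The step that the limit leaves unreadable from compound 1 to compound 4 is expected to be nil.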

Compound 4, half-maximal cytotoxic concentration: > 33000 nM
Compound 4: no number, only a limit; the forecaster's own chance of this, stated with the estimate: 80%; the middle value does not contradict the limit.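

In this assay compound 1 remains a limit, > 33000 nM. Compound 4 is also only a limit, > 33000 nM, so no step can be read from it against compound 1. Still open, from the compounds shown here alone, is whether (5-fluoropyridin-2-yl)methyl to ethyl shifts this read-out at all.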